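A few compounds are considered here, and "the series" means these few. Any claim that something is new, unique, unknown or untested is made for them only; others in the source may bear on it.

Measured in a functional assay on Caco-2 cells (Homo sapiens) for inhibition, read by MTT assay, with a stated time of 48 h, tested at 10 uM; on this read-out lower numbers stand for less inhibition of growth and higher numbers for more inhibition of growth at the one concentration tested:

- compound 1 `Cc1oc2c([C@H]3CCN(C)C[C@H]3O)c(O)cc(O)c2c(=O)c1C(O)c1ccc(F)c(Br)c1`: 6%
- compound 2 `Cc1oc2c([C@H]3CCN(C)C[C@H]3O)c(O)cc(O)c2c(=O)c1C(O)c1c(Cl)cccc1Cl`: 24%
- compound 3 `Cc1oc2c([C@H]3CCN(C)C[C@H]3O)c(O)cc(O)c2c(=O)c1C(O)c1csc([N+](=O)[O-])c1`: 3%

Among these three, the data show a number 3 percentage points lower from compound 1 to compound 3 (within the scatter), so compound 3 and compound 1 cannot be told apart. They also show a number 21 percentage points lower from compound 2 to compound 3 (beyond the scatter). The next compound to consider is compound 4 `COc1ccc(C(O)c2c(C)oc3c([C@H]4CCN(C)C[C@H]4O)c(O)cc(O)c3c2=O)cc1Br`, in which 3-bromo-4-methoxyphenyl takes the place of 5-nitrothiophen-3-yl on a saturated chain carbon bound to an aromatic carbon and an oxygen on a saturated carbon: 3-bromo-4-methoxyphenyl in place of 5-nitrothiophen-3-yl on a saturated chain carbon bound to an aromatic carbon and an oxygen on a saturated carbon.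

The most relevant comparison is with compound 1, whose 3-bromo-4-fluorophenyl group also carries bromine on a phenyl ring. Its exchange for the same 5-nitrothiophen-3-yl group gave a number 3 percentage points lower from compound 1 to compound 3 (within the scatter). The larger change came only with the 2,6-dichlorophenyl group of compound 2, seen in a number 18 percentage points higher from compound 1 to compound 2 (beyond the scatter), and compound 4 does not carry that group. In this assay, the expected change is therefore small: a number 4 percentage points higher from compound 3 to compound 4 (within the scatter). For compound 4, the estimated value is 7%, with an expected range from 0% to 20%.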

Compound 4, percent growth inhibition at one concentration: 0%
For compound 4 the middle estimate is 7 percentage points above the measured one, and the stated range covers the measured number.
By their numbers in this assay, from the lowest: compounds 4, 3 and 1 (each within the scatter of the next); then compound 2.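

In this assay the data give a number 3 percentage points lower from compound 3 to compound 4 (within the scatter) and a number 6 percentage points lower from compound 1 to compound 4 (within the scatter) for methoxy in place of fluoro on an aromatic carbon, so compound 4 cannot be told apart from compound 3 or compound 1. The gap to the 2,6-dichlorophenyl group holds for this third group as well, with a number 24 percentage points lower from compound 2 to compound 4 (beyond the scatter) and so, among the four, compound 2 alone stands apart while the other three sit together. Nothing measured here gives a reason for this separation.

As far as these compounds go, it remains open whether a phenyl ring with a single chloro group would keep the number seen for compound 2. From the compounds shown here alone, it is also open whether an aminophenyl or a carboxyphenyl group on this saturated chain carbon would move the number away from the three that sit together.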